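The compounds below may be only part of what the source reports. "The series", "measured", "known", "first", "only" and "open" are said of these compounds alone.

Working notes on the series.

The series is assessed in an ADME assay on Vero cells (Chlorocebus sabaeus) for cytotoxicity, read by resazurin assay, with a stated time of 2 days; a lower number here means that less compound is tolerated, a higher number that more compound is tolerated. Compound 1 is `CC(=O)OC[C@H]1O[C@@H](CC(=O)/C=C/c2cccc(NS(=O)(=O)c3ccc(C)cc3)c2)[C@H](OC(C)=O)[C@@H](OC(C)=O)[C@@H]1OC(C)=O`; in this assay compound 1 gives 584000 nM. Compound 3, whose structure is `Cc1ccc(S(=O)(=O)Nc2cccc(/C=C/C(=O)C[C@@H]3O[C@H](CO)[C@@H](O)[C@H](O)[C@H]3O)c2)cc1`, gives in this assay 381000 nM. Compound 2, whose structure is `O=C(/C=C/c1cccc(NC(=S)Nc2ccccc2)c1)C[C@@H]1O[C@H](CO)[C@@H](O)[C@H](O)[C@H]1O`, gives in this assay 371000 nM. The three numbers lie within the usual scatter of one another, so no order among them is read.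

Compound 3 and compound 2 differ in one place: a group of 9 heavy atoms (7 carbon, 1 nitrogen, 1 sulfur; one six-membered aromatic ring of carbon only) in place of a group of 10 heavy atoms (7 carbon, 2 oxygen, 1 sulfur; one six-membered aromatic ring of carbon only), on a nitrogen on an aromatic ring. Across that change the step is a 1.0-fold lower number from compound 3 to compound 2 (0.01 log units; within the scatter).

Compound 1 and compound 3 carry different cores; how the two cores differ is not broken down here.

Compound 4, not yet measured in this assay, is `CC(=O)OC[C@H]1O[C@@H](CC(=O)/C=C/c2cccc(NC(=S)Nc3ccccc3)c2)[C@H](OC(C)=O)[C@@H](OC(C)=O)[C@@H]1OC(C)=O`. It relates to compound 1 as compound 2 relates to compound 3: a group of 9 heavy atoms (7 carbon, 1 nitrogen, 1 sulfur; one six-membered aromatic ring of carbon only) in place of a group of 10 heavy atoms (7 carbon, 2 oxygen, 1 sulfur; one six-membered aromatic ring of carbon only), on a nitrogen on an aromatic ring. The place of the change is worded the same in both cases, so this is the same change, carried out on the core of compound 1 instead of the core of compound 3. Among the compounds shown the change occurs twice in all.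

For compound 4 the expected step is a 1.0-fold lower number from compound 1 to compound 4 (0.01 log units; within the scatter). This expectation rests on the fact that a 1.0-fold lower number from compound 3 to compound 2 (0.01 log units; within the scatter), and on nothing beyond these compounds. For compound 4 the number expected in this assay is therefore 570000 nM, with an estimated range from 300000 nM to 1000000 nM.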

Compound 4, half-maximal cytotoxic concentration: 337000 nM
For compound 4 the middle estimate is 1.7-fold (0.23 log units) above the measured one; the measured number falls inside the stated range.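

In this assay, placing the new group on the nitrogen on an aromatic ring, where (4-methylphenyl)sulfonyl stood, gives a 1.7-fold lower number from compound 1 to compound 4 (0.24 log units; within the scatter). The step on this core and the earlier step on the other core do not differ beyond what repeated measurement allows, so the exchange reads the same on both cores: the same change on two cores in this assay, a 1.0-fold lower number (0.01 log units; within the scatter) from compound 3 to compound 2 and a 1.7-fold lower number (0.24 log units; within the scatter) from compound 1 to compound 4, 1.7-fold (0.23 log units) apart, within the scatter of two such steps. This shows only that, for two pairs of compounds in one assay, neither core gives a step beyond the scatter; since neither step is beyond the scatter, the comparison shows agreement between two small steps, and it does not show that the change would behave the same way on a further core or in another assay.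

The compounds shown leave open whether a different group on that nitrogen, such as a longer alkyl chain, an amine-bearing chain or a chain ending in a carboxylic acid, would give a step beyond the scatter in this assay. They also leave open whether the exchange of (4-methylphenyl)sulfonyl for the new group would read the same on any core other than the two shown here.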